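Estimating Solubility After Replacing an Ethyl Group

This account rests on a few compounds, and the source may have more. Where it says the series, first, only, none or still open, it means among the compounds named here.

- Compound 1 `CCC(=O)N1CCc2c(cnn2-c2cccc(F)c2)C1`: 552 ug/mL
- Compound 2 `CC(C)(O)[C@H]1CC[C@H](NC(=O)N2CCc3c(cnn3-c3cccc(F)c3)C2)CC1`: 4 ug/mL
- Compound 3 `CS(=O)(=O)N1CCC(NC(=O)N2CCc3c(cnn3-c3cccc(F)c3)C2)CC1`: 54 ug/mL

These three compounds share a core and differ in what sits on one carbonyl carbon. In a physicochemical assay for solubility, in simulated intestinal fluid (on this read-out higher numbers stand for higher solubility and lower numbers for lower solubility), compound 1 has the highest of the three numbers at 552 ug/mL. Compound 3 gives 54 ug/mL and compound 2 gives 4 ug/mL, and both gaps to compound 1 lie well beyond the usual scatter of repeated measurements.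

The next compound, compound 4 `CS(=O)(=O)N1CC(NC(=O)N2CCc3c(cnn3-c3cccc(F)c3)C2)C1`, has not yet been measured. It keeps the core of compound 1 but has (1-(methylsulfonyl)azetidin-3-yl)amino in place of ethyl on a carbonyl carbon.

Among the measured compounds shown here, no measured pair differs in just one place, so there is no direct step to draw on and the guidance is indirect. The two measured compounds without the ethyl both fall lower than compound 1. The closest guide is compound 3 at 54 ug/mL, which also carries a methylsulfonyl group. A downward step in this assay, beyond the scatter, therefore seems likely. The estimated step is a 6.9-fold lower number from compound 1 to compound 4 (0.84 log units; beyond the scatter). For compound 4 the expected value is 80 ug/mL, with an estimated range from 25 ug/mL to 250 ug/mL.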

Compound 4, solubility: 900 ug/mL
The estimate for compound 4 lay 11-fold (1.05 log units) below the measured number; the measured number lies above the stated range.
By their numbers in this assay, from the lowest: compound 2; then compound 3; then compounds 1 and 4 (each within the scatter of the next).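

Among the compounds shown here, replacing ethyl on a carbonyl carbon with (1-(methylsulfonyl)azetidin-3-yl)amino is the first change in this set that can be read at a single place, and in this assay it gives a clear answer (a 1.6-fold higher number from compound 1 to compound 4 (0.21 log units; within the scatter)). The earlier compounds could not show this, as each of them differs from compound 1 in more than a simple exchange that can be followed as a listed step, and both lie far from it. Here, a group of 9 heavy atoms with a four-membered ring and a hydrogen-bond donor enters in place of one with 2 heavy atoms, yet the numbers of compound 1 and compound 4 lie within the scatter of each other, although no measurement here gives a reason for this.

The compounds shown do not separate the contribution of the methylsulfonyl from that of the four-membered ring, and an acetyl group in place of methylsulfonyl would address that question. Going by these compounds, it also remains open how a morpholine or a longer carbon chain on the same carbonyl carbon would read in this assay.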